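The source may report more compounds than this note shows. Statements on the series, on what has been measured and on what is new or still open speak of the compounds shown alone.

Series notes. Compound 1 `Cc1cccc(NC(=O)Nc2cccc(CNc3nccnc3Cl)c2)c1` and compound 2 `O=C(Nc1ccc(C(F)(F)F)cc1)Nc1cccc(CNc2nccnc2Cl)c1` share one core and have been run in a functional assay on HepG2 cells (Homo sapiens) for antiproliferative activity, read by MTT assay, with a stated time of 48 h; on this read-out higher numbers stand for weaker inhibition and lower numbers for stronger inhibition. Compound 1 gives 11200 nM, the higher of the two numbers; compound 2 gives 5050 nM, a gap beyond the usual scatter. Compound 3 `Cc1ccc(NC(=O)Nc2cccc(CNc3nccnc3Cl)c2)cc1Cl` is not yet measured; it differs from compound 1 by 3-chloro-4-methylphenyl in place of 3-methylphenyl on an amide-type nitrogen. Going by the values given here, no measured pair isolates this change, so the direction rests on the two numbers alone. A modest step downward from compound 1 is expected, a 1.6-fold lower number from compound 1 to compound 3 (0.20 log units; within the scatter), within the scale seen between compounds 1 and 2. Compound 3 is therefore estimated at 7000 nM in this assay, with a range from 3000 nM to 16000 nM.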

Compound 3, half-maximal inhibitory concentration: 11300 nM
The estimate for compound 3 lay 1.6-fold (0.21 log units) below the measured number; the range from low to high includes it.
By their numbers in this assay, from the lowest: compound 2; then compounds 1 and 3 (each within the scatter of the next).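

Going by these compounds alone, replacing 3-methylphenyl with 3-chloro-4-methylphenyl on the amide-type nitrogen gives a 1.0-fold higher number from compound 1 to compound 3 (0.00 log units; within the scatter) in this assay, the first step that isolates a change at this position. At this position, then, the new chlorine and the altered methyl placement together leave the number unmoved beyond the scatter. No measured evidence on this result is available to explain it.

As far as these compounds go, whether an amine, a carboxylic acid or a methoxy group on this phenyl ring would shift the number remains open. Changes to the shared core also remain open.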